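Heteroaryl swap on the amine side, cytotoxicity outlook

The compounds below may be only part of what the source reports. "The series", "measured", "known", "first", "only" and "open" are said of these compounds alone.

Of the compounds shown here, two of the shared core have been measured in an ADME assay on MDCK cells (Canis lupus familiaris) for cytotoxicity, read by microscopy, with a stated time of 48 h; on this read-out higher numbers stand for lower toxicity in this test and lower numbers for higher toxicity in this test. Compound 1 `CCCCc1ccsc1CN[C@@H]1C[C@H]2C[C@@H]([C@H]1C)C2(C)C` gives 25000 nM in this assay. Compound 2 `C[C@H]1[C@H](NCc2cncnc2)C[C@H]2C[C@@H]1C2(C)C` is reported only as a limit of the assay, > 100000 nM in this assay. Among the measured compounds shown here, compound 2 therefore stands at the limit itself the limit of > 100000 nM in this assay, at which 1 of the 2 values shown sits, and carries no number of its own, so no step between measured compounds can be drawn from it. Compound 3 `Cc1csc(CN[C@@H]2C[C@H]3C[C@@H]([C@H]2C)C3(C)C)n1` is not yet measured; it differs from compound 2 by 4-methyl-1,3-thiazol-2-yl in place of pyrimidin-5-yl on a saturated chain carbon bound to an amine nitrogen. The two values shown do not tell whether this change moves the read-out. Since compound 2 sits at a limit, the step of an at least 1.6-fold lower number from compound 2 to compound 3 (0.22 log units; that floor lies within the scatter) is expected to be a small move toward higher toxicity, close to the scatter. For compound 3 the expected value in this assay is 60000 nM, ranging from 20000 nM to 100000 nM, with a fair chance that only a limit is again reported.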

Compound 3, minimum cytotoxic concentration: > 100000 nM
Compound 3 ended at the assay's limit; the forecaster's own chance of this, stated with the estimate: 40%; middle value at least 1.6-fold (0.22 log units) away from the limit.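

Compound 2 and compound 3 are both reported only as a limit, so no step can be read between them: the limit of > 100000 nM in this assay, at which 2 of the 3 values shown sit. On these data alone, it remains open whether 4-methyl-1,3-thiazol-2-yl in place of pyrimidin-5-yl moves the read-out at all, and how far either compound lies beyond that limit.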